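Removing a Hydroxymethyl from a Kinase Activator Scaffold

The source may hold more compounds than are shown below. What is called first, only, known or untested is meant among the compounds shown, and "the series" means these compounds.

Compound 1 `OC[C@@H](O[C@H]1CCCN(Cc2ncc[nH]2)[C@H]1c1ccccc1)c1cc(Cl)cc(Cl)c1` holds the lowest number of the three measured compounds: in an assay on isolated protein for activation of cGMP-dependent protein kinase 1 (Homo sapiens), read by ADP-Glo, with stated times of 120 min and 40 min (on this read-out lower numbers stand for an effect already at smaller amounts and higher numbers for an effect only at larger amounts of compound), compound 1 gives 7000 nM. Compound 2 `O=C(O)c1ccc(CN2CCC[C@H](OCc3cc(Cl)cc(Cl)c3)[C@@H]2c2ccccc2)s1` gives 76000 nM and compound 3 `Clc1cc(Cl)cc(CO[C@H]2CCCN(Cc3ccc(-c4nn[nH]n4)cc3)[C@H]2c2ccccc2)c1` gives 74000 nM, both beyond the scatter from compound 1. For the measured compounds named here, the single measured step, a 1.0-fold lower number from compound 2 to compound 3 (0.01 log units; within the scatter), changes the group on a saturated chain carbon bound to an amine nitrogen in a ring and leaves the number essentially unchanged. Compound 4 `Clc1cc(Cl)cc(CO[C@H]2CCCN(Cc3ncc[nH]3)[C@H]2c2ccccc2)c1` differs from compound 1 elsewhere: hydrogen in place of hydroxymethyl on a saturated chain carbon bound to an aromatic carbon and an oxygen on a saturated carbon. Going by the values given here, no measured step touches this place, so the only guide is that compound 1 carries the lowest number so far. A modest loss is expected, a 2.1-fold higher number from compound 1 to compound 4 (0.33 log units; beyond the scatter). Compound 4 is estimated at 15000 nM, within 3500 nM to 60000 nM.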

Compound 4, half-maximal effective concentration in the cGMP-dependent protein kinase 1 assay: 47000 nM
Compound 4: the middle estimate sits 3.1-fold (0.50 log units) below what was measured; the range from low to high includes it.
By their numbers in the cGMP-dependent protein kinase 1 assay, from the lowest: compound 1; then compounds 4, 3 and 2 (each within the scatter of the next).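

In the cGMP-dependent protein kinase 1 assay the hydroxymethyl matters at this position: removing it gives a 6.7-fold higher number from compound 1 to compound 4 (0.83 log units; beyond the scatter) while, with it gone, exchanging the group on the amine nitrogen leaves the numbers within the scatter, at a 1.6-fold lower number from compound 3 to compound 4 (0.20 log units; within the scatter) and a 1.6-fold lower number from compound 2 to compound 4 (0.21 log units; within the scatter). In a physicochemical assay for solubility, read by HPLC, with a stated time of 24 h, at pH 7 (a lower number here means a less soluble compound, a higher number a more soluble compound), compound 1 gives 60000 nM and compound 4 gives 120000 nM, which lie within the scatter of each other. Nothing available explains the loss.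

On these data alone, whether a methyl or an aminomethyl at this place would keep the lower number remains open. So does whether adding hydroxymethyl to compound 2 or compound 3 would lower their numbers.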